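Butoxy in Place of Pyrrolidinyl on a Methylenecyclopropane Purine

This account rests on a few compounds, and the source may have more. Where it says the series, first, only, none or still open, it means among the compounds named here.

Compound 3 `Nc1nc(N2CCCC2)c2ncn(/C=C3/CC3(CO)CO)c2n1` carries a pyrrolidin-1-yl group on its core, and in an ADME assay on MOLT-3 cells (Homo sapiens) for cytotoxicity, with a stated time of 7 days (on this read-out higher numbers stand for lower toxicity in this test and lower numbers for higher toxicity in this test), compound 3 is recorded only as "not determined" (no result reported), so no number places it among its neighbours. Compound 1 `Nc1nc(NCc2ccccc2)c2ncn(/C=C3/CC3(CO)CO)c2n1` sits at a limit of this assay, giving > 20000 nM. Compound 2 `Nc1nc2c(ncn2/C=C2/CC2(CO)CO)c(=O)[nH]1` likewise reaches only a limit, > 20000 nM. Both of these values rest at the limit of > 20000 nM in this assay, at which 2 of the 3 values shown sit. Compound 4 `CCCCOc1nc(N)nc2c1ncn2/C=C1/CC1(CO)CO` differs from compound 3 by butoxy in place of pyrrolidin-1-yl on an aromatic carbon. Among the measured compounds shown here, no measured step between neighbours exists here, so the size of this change in this assay cannot be read from the data; no shift beyond the scatter is expected, and a limit seems the likely outcome. Compound 4 is therefore estimated at 40000 nM, within 15000 nM to 100000 nM.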

Compound 4, half-maximal cytotoxic concentration: > 20000 nM
Compound 4 was reported as a limit; the forecaster's own chance of this, stated with the estimate: 85%; the middle value does not contradict the limit.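

Compound 1 and compound 4 both rest at a limit of this assay, so no size can be read for the step between them: the limit of > 20000 nM in this assay, at which 3 of the 4 values shown sit.

The compounds shown leave open where compound 3 stands and how far apart the other three truly lie.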